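Branched side chain on the aromatic nitrogen: compound 3 to compound 4

The source may report more compounds than this note shows. Statements on the series, on what has been measured and on what is new or still open speak of the compounds shown alone.

Compound 3 `C/C(=C\C(=O)Nc1ccccc1OCCCC(=O)O)c1ccc2c(ccn2C(C(C)C)C(C)C)c1` stands second highest of the three numbers in an assay on Prostate gland for inhibition of steroid 5-alpha-reductase (Rattus norvegicus) (on this read-out lower numbers stand for stronger inhibition and higher numbers for weaker inhibition), giving 14 nM. Compound 2 `CCCCC(C)n1ccc2cc(/C(C)=C/C(=O)Nc3ccccc3OCCCC(=O)O)ccc21` gives 6 nM, and compound 1 `CCCn1ccc2cc(/C(C)=C/C(=O)Nc3ccccc3OCCCC(=O)O)ccc21` gives 190 nM. The steps of a 32-fold lower number from compound 1 to compound 2 (1.50 log units; beyond the scatter) and a 14-fold lower number from compound 1 to compound 3 (1.13 log units; beyond the scatter) show that a branched group on the aromatic nitrogen in place of propyl gives a much lower number, whereas a 2.3-fold higher number from compound 2 to compound 3 (0.37 log units; beyond the scatter) is modest. Compound 4 `CCCCC(c1ccccc1)n1ccc2cc(/C(C)=C/C(=O)Nc3ccccc3OCCCC(=O)O)ccc21` differs from compound 3 by 1-phenylpentyl in place of 1-isopropyl-2-methylpropyl on an aromatic nitrogen; a branched group remains on the aromatic nitrogen. Because compound 2 gives 6 nM and compound 3 gives 14 nM, a number in that range is expected for compound 4, and the step of a 1.8-fold lower number from compound 3 to compound 4 (0.24 log units; within the scatter) is expected to be modest, toward a lower number. Compound 4 is estimated at 8 nM, within 2.5 nM to 30 nM.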

Compound 4, half-maximal inhibitory concentration: 9.8 nM
Beside the measured number, compound 4's estimate is 1.2-fold (0.09 log units) below it, and the stated range covers the measured number.
By their numbers in this assay, from the lowest: compounds 2, 4 and 3 (each within the scatter of the next, the first and the last beyond it); then compound 1.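

On the aromatic nitrogen, a branched group can carry a six-membered aromatic ring of carbon only: a 1.4-fold lower number from compound 3 to compound 4 (0.15 log units; within the scatter) and a 1.6-fold higher number from compound 2 to compound 4 (0.21 log units; within the scatter) both stay within the scatter, so 1-phenylpentyl cannot be told apart from 1-isopropyl-2-methylpropyl or 1-methylpentyl. Against propyl the ring-bearing group behaves like the other two branched groups, with a 19-fold lower number from compound 1 to compound 4 (1.29 log units; beyond the scatter) as its step. No evidence bears on what lies behind these numbers.

Still open, as far as these compounds go, is whether a pyridyl group in place of phenyl keeps the number in this range. The same holds for an amine on the 1-phenylpentyl chain.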